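Methoxy on the lowest of three measured compounds

This account rests on a few compounds, and the source may have more. Where it says the series, first, only, none or still open, it means among the compounds named here.

Within the data shown here, in a physicochemical assay for solubility, in phosphate buffer, measured as kinetic solubility, with a stated time of 24 h, at pH 6.5 (a lower number here means a less soluble compound, a higher number a more soluble compound), compound 2 (`CC(C)Oc1cc(Oc2ccc(S(C)(=O)=O)cc2)cc(-c2nccc(=O)[nH]2)c1`) gives 25000 nM, the lowest of the three numbers measured so far. Compound 1 (`CC(C)Oc1cc(Oc2ccc(S(C)(=O)=O)cc2)cc(-c2cncc(=O)[nH]2)c1`) gives 118000 nM, and compound 3 (`CCS(=O)(=O)c1ccc(Oc2cc(O[C@@H](C)CO)cc(-c3nccc(=O)[nH]3)c2)cc1`) gives 390000 nM, both beyond the scatter from compound 2. Compound 4 (`COc1cnc(-c2cc(Oc3ccc(S(C)(=O)=O)cc3)cc(OC(C)C)c2)[nH]c1=O`) has not yet been measured. Its difference from compound 2 is methoxy in place of hydrogen on an aromatic carbon.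

Among the measured compounds shown here, only one measured step bears on this change, and only loosely. It is a 4.7-fold lower number from compound 1 to compound 2 (0.67 log units; beyond the scatter), a modest step that swaps one six-membered aromatic ring with 2 hetero atoms for another. For the measured compounds named here, that step adds no methoxy, and no measured pair tests this group, so the data give no direction for the change. The expected size of the step is therefore none beyond the scatter, and the estimate is a 1.1-fold lower number from compound 2 to compound 4 (0.06 log units; within the scatter). Compound 4 is expected to give about 22000 nM, with an estimated range from 7000 nM to 70000 nM.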

Compound 4, solubility: 7100 nM
Compound 4: the middle estimate sits 3.1-fold (0.49 log units) above what was measured, within the range that was stated.
By their numbers in this assay, from the lowest: compound 4; then compound 2; then compound 1; then compound 3.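

In this assay this position now has a measured direction: methoxy in place of hydrogen, on an aromatic carbon two atoms from the ring nitrogen, goes with a 3.5-fold lower number from compound 2 to compound 4 (0.55 log units; beyond the scatter) as a modest step. The ring change and the methoxy together give a 17-fold lower number from compound 1 to compound 4 (1.22 log units; beyond the scatter) as a large step, and this goes the same way as a 4.7-fold lower number from compound 1 to compound 2 (0.67 log units; beyond the scatter) on its own. No measurement shown here accounts for the methoxy step.

The compounds shown leave open whether a longer chain such as ethoxy, or an amine, on this same aromatic carbon would give a step of like direction and size. They also leave open whether methoxy would move the number the same way on the core of compound 3.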